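Toward Compound 4: An Amine Replaces the Pyridinyl Ether

The compounds below may be only part of what the source reports. "The series", "measured", "known", "first", "only" and "open" are said of these compounds alone.

Compound 1 `Cc1cc(Oc2ccc(-c3ccn4c(CC5CC5)nnc4c3Cl)cc2F)ccn1` carries the highest number of three compounds in a functional assay on cells for positive allosteric modulation of metabotropic glutamate receptor 2 (Homo sapiens), read by scintillation counting and GTPgammaS binding, with a stated time of 30 min (on this read-out lower numbers stand for an effect already at smaller amounts and higher numbers for an effect only at larger amounts of compound), where compound 1 gives 251 nM. Nearest to it is compound 2 `Cc1cc(Oc2ccc(-c3ccn4c(CC5CC5)nnc4c3C(F)(F)F)cc2F)ccn1`, which in this assay gives 56.2 nM; furthest is compound 3 `CCOCc1nnc2c(C(F)(F)F)c(-c3ccc(Oc4ccc(C)nc4C)c(F)c3)ccn12`, which in this assay gives 29.5 nM. Within the data shown here, only one change is measured as a clean step: a 4.5-fold lower number from compound 1 to compound 2 (0.65 log units; beyond the scatter), on the shared core. Compound 3 differs from compound 2 in more than one place, so its two values show only that both lie well under compound 1.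

Compound 4 `Fc1cc(-c2ccn3c(CC4CC4)nnc3c2Cl)ccc1NC1CC1` is not yet measured. It differs from compound 1 by cyclopropylamino in place of (2-methylpyridin-4-yl)oxy on an aromatic carbon, on an aromatic carbon of a six-membered aromatic ring of carbon only, ortho to a fluoro group. Among the measured compounds shown here, no measured step touches this group: the step from compound 1 to compound 2 concerns the exchange of chloro for trifluoromethyl on the core, and the (2-methylpyridin-4-yl)oxy group is kept in every measured compound. The expectation for compound 4 therefore rests on the structural change alone, and is expected to be a 3.2-fold higher number from compound 1 to compound 4 (0.50 log units; beyond the scatter), toward higher numbers, with wide uncertainty. Compound 4 is estimated to give 800 nM, within a range from 200 nM to 4000 nM.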

Compound 4, half-maximal effective concentration: 63.1 nM
Estimate against measurement, compound 4: 13-fold (1.10 log units) above, and the stated range ends above it.
By their numbers in this assay, from the lowest: compounds 3, 2 and 4 (each within the scatter of the next, the first and the last beyond it); then compound 1.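

In this assay, among these compounds, the exchange of (2-methylpyridin-4-yl)oxy for cyclopropylamino gives a 4.0-fold lower number from compound 1 to compound 4 (0.60 log units; beyond the scatter) and is the first measured step at this place, on an aromatic carbon ortho to a fluoro group. It shows that activity on the shared core does not depend on the six-membered aromatic ring with 1 hetero atom: a group of 4 heavy atoms, with a three-membered ring and 1 hydrogen-bond donor, stands in place of one with 8 heavy atoms, and the number goes down rather than up. Nothing in the material at hand accounts for this drop, so the result stands as an observation only.

The compounds shown leave open whether the lower number seen with trifluoromethyl in place of chloro would carry over to a compound with cyclopropylamino at this place. They also leave open what the amine hydrogen and the small ring each contribute, a question that cyclopropyloxy, with an oxygen in place of the amine nitrogen, or dimethylamino, an amine without that hydrogen or ring, could help to answer.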